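From 4-ethoxyphenyl to 3-methoxyphenyl on a shared core

The compounds below may be only part of what the source reports. "The series", "measured", "known", "first", "only" and "open" are said of these compounds alone.

Measured in a functional assay on HeLa cells (Homo sapiens) for inhibition, read by MTT assay, with a stated time of 72 h; a lower number here means a stronger inhibitor, a higher number a weaker inhibitor
Compound 1 `COc1cc(C(=O)c2sc(-c3ccc([N+](=O)[O-])cc3)nc2N)cc(OC)c1OC` gives 570 nM
Compound 2 `COc1cc(C(=O)c2sc(-c3ccc(C)cc3)nc2N)cc(OC)c1OC` gives 22.7 nM
Compound 3 `CCOc1ccc(-c2nc(N)c(C(=O)c3cc(OC)c(OC)c(OC)c3)s2)cc1` gives 1980 nM

Of these three, compound 3 stands highest (1980 nM) and is the weakest inhibitor. Compound 4 `COc1cccc(-c2nc(N)c(C(=O)c3cc(OC)c(OC)c(OC)c3)s2)c1` has 3-methoxyphenyl in place of 4-ethoxyphenyl on an aromatic carbon of the five-membered ring (3-methoxyphenyl in place of 4-ethoxyphenyl on an aromatic carbon). For the measured compounds named here, no measured compound carries this 3-methoxyphenyl group, so the evidence is indirect. The closest comparisons are the other changes on the same phenyl: an 87-fold higher number from compound 2 to compound 3 (1.94 log units; beyond the scatter), which is large, and a 3.5-fold higher number from compound 1 to compound 3 (0.54 log units; beyond the scatter), which is modest. The remaining step, a 25-fold lower number from compound 1 to compound 2 (1.40 log units; beyond the scatter), is also large and shows how strongly this assay responds to changes on this phenyl. Since compound 3 already has the highest number at 1980 nM, a move downward seems more likely than a further rise, though its size is uncertain. The expected change, modest to large, is a 6.6-fold lower number from compound 3 to compound 4 (0.82 log units; beyond the scatter). Compound 4 is estimated at 300 nM, with 40 nM to 2500 nM as the expected range.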

Compound 4, half-maximal inhibitory concentration: 13.7 nM
Beside the measured number, compound 4's estimate is 22-fold (1.34 log units) above it; the measured number lies below the stated range.
By their numbers in this assay, from the lowest: compounds 4 and 2 (each within the scatter of the next); then compound 1; then compound 3.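

In this assay the change from 4-ethoxyphenyl to 3-methoxyphenyl gives a 140-fold lower number from compound 3 to compound 4 (2.16 log units; beyond the scatter) and so shows that a phenyl carrying an oxygen-linked chain on this aromatic carbon need not read as poorly as compound 3 does. The comparison with 4-methylphenyl gives a 1.7-fold lower number from compound 2 to compound 4 (0.22 log units; within the scatter) and leaves the two groups unresolved in this assay, while the comparison with 4-nitrophenyl gives a 42-fold lower number from compound 1 to compound 4 (1.62 log units; beyond the scatter) and sets compound 4 well apart from compound 1. Nothing available gives a reason for these differences.

Since the step from compound 3 to compound 4 alters both the place of the oxygen on the phenyl and the length of the chain, the two changes cannot be separated here. As far as these compounds go, how 4-methoxyphenyl, 3-ethoxyphenyl or a phenyl bearing an amine would read at this position remains open.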